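The source may hold more compounds than are shown below. What is called first, only, known or untested is meant among the compounds shown, and "the series" means these compounds.

Measured so far:

Compound 1, `CC(Cn1ncccc1=O)C(=N)S`. In a functional assay on the whole organism (stomach) with Rattus norvegicus as the target (on this read-out lower numbers stand for an effect already at smaller amounts and higher numbers for an effect only at larger amounts of compound), compound 1 gives > 100 mg/kg, which is a limit of the assay and not a number.

Compound 2, `N=C(S)CCn1ncccc1=O`. In this assay compound 2 gives > 100 mg/kg, again a limit of the assay.

Compound 3, `Cc1ccc(=O)n(C(C)CC(=N)S)n1`. In this assay compound 3 gives > 100 mg/kg, also a limit of the assay.

Working notes. The change from compound 1 to compound 2 is hydrogen in place of methyl on a saturated chain carbon bound to a carbon with a double bond to nitrogen and a saturated chain carbon. The step it makes is a step that the two limits leave unreadable from compound 1 to compound 2, so its size cannot be read from these two compounds. Compound 3 carries a different core from compound 1; the difference between the two cores is not broken down here. Compound 4, `Cc1ccc(=O)n(CCC(=N)S)n1`, is not yet measured. It is related to compound 3 by hydrogen in place of methyl on a saturated chain carbon bound to an aromatic nitrogen and a saturated chain carbon. Among the measured compounds shown here, this is the same kind of change as the one from compound 1 to compound 2, but not the same change: there the methyl left a saturated chain carbon bound to a carbon with a double bond to nitrogen and a saturated chain carbon, here it leaves a saturated chain carbon bound to an aromatic nitrogen and a saturated chain carbon.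

For the measured compounds named here, the only evidence on the measured step is the limit of > 100 mg/kg in this assay, at which 3 of the 3 values shown sit. With every measured value sitting at that limit, the expectation for compound 4 can rest on nothing but this, and a step that the limit leaves unreadable from compound 3 to compound 4 is expected, meaning compound 4 is also expected to reach the limit rather than give a number. For compound 4 in this assay the estimate is 200 mg/kg, with a range from 80 mg/kg to 600 mg/kg, and a reading that is only a limit is expected most of the time.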

Compound 4, dose for half-maximal effect: 43.2 mg/kg
Estimate against measurement, compound 4: 4.6-fold (0.67 log units) above; the measured number lies below the stated range.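

Working notes. In this assay, hydrogen in place of methyl on a saturated chain carbon bound to an aromatic nitrogen and a saturated chain carbon gives an at least 2.3-fold lower number from compound 3 to compound 4 (0.36 log units; beyond the scatter), and methyl in place of hydrogen on an aromatic carbon gives an at least 2.3-fold lower number from compound 2 to compound 4 (0.36 log units; beyond the scatter); each size is only a lower bound, since compound 3 and compound 2 stand at a limit of the assay and not at a number. Within the core of compound 4, then, the removal of this methyl does show a change beyond the scatter, and compound 4 is the only compound shown that gives a number. It does not show that the change carries from one core to another, since the related step in the other core cannot be read and there the methyl leaves a different carbon, so the transfer stays untested, with most of the series still at the ceiling of the assay: the limit of > 100 mg/kg in this assay, at which 3 of the 4 values shown sit.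

Open, as far as these compounds go, is how far the number moves with an ethyl or a longer chain in place of that methyl on the saturated chain carbon. Equally open, from the compounds shown here alone, is whether an amine or a carboxylic acid in place of the methyl on the aromatic carbon would keep a readable number.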